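Swapping 2-chlorophenyl for 1,1-dioxothian-4-yl on a shared core

A few compounds are considered here, and "the series" means these few. Any claim that something is new, unique, unknown or untested is made for them only; others in the source may bear on it.

Measured compounds in an in vitro ADME assay on microsomes from liver (Rattus norvegicus) for metabolic stability (a higher number here means faster removal of the compound, a lower number slower removal), are as follows
- Compound 1 `O=C(NC1CCCCC1)N1CCN(c2nc(-c3ccc4ccccc4n3)no2)CC1` gives 189 mL.min-1.g-1 as a number
- Compound 2 `O=C(Nc1ccccc1Cl)N1CCC(c2nc(-c3ccc4ccccc4n3)no2)CC1` gives > 200 mL.min-1.g-1 as a limit

Compound 1 has a measured number, 189 mL.min-1.g-1, in this assay and so gives a fixed reference point. Compound 2 has no such number. Its reading of > 200 mL.min-1.g-1 is a limit of the assay, and it sits at the limit of > 200 mL.min-1.g-1 in this assay, at which 1 of the 2 values shown sits, so only that limit can be stated for it.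

Compound 3 `O=C(NC1CCS(=O)(=O)CC1)N1CCC(c2nc(-c3ccc4ccccc4n3)no2)CC1` keeps the rest of compound 2 and carries 1,1-dioxothian-4-yl in place of 2-chlorophenyl on an amide-type nitrogen. Going by the values given here, no measured pair of compounds sizes this change directly, so the expectation rests on the structural change alone. A clear drop beyond the scatter is expected in this assay, towards slower removal. The size of that drop stays uncertain because compound 2 reads > 200 mL.min-1.g-1, which is a limit. The estimated change an at least 3.3-fold lower number from compound 2 to compound 3 (0.52 log units; beyond the scatter) is therefore only a rough figure. For compound 3 the estimated value is 60 mL.min-1.g-1, with an expected range from 20 mL.min-1.g-1 to 150 mL.min-1.g-1, and the measurement is still to come.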

Compound 3, intrinsic clearance in microsomes: 8 mL.min-1.g-1
For compound 3 the middle estimate is 7.5-fold (0.88 log units) above the measured one; the measured number lies below the stated range.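

In this assay, the group on the amide-type nitrogen proves to have a strong hold on the reading for this shared core: 1,1-dioxothian-4-yl in place of 2-chlorophenyl gives an at least 25-fold lower number from compound 2 to compound 3 (1.39 log units; beyond the scatter). Going by these compounds alone, compound 3, at 8 mL.min-1.g-1, gives the first measured number for this core and shows that the position can move the reading far, which neither earlier compound could show, as no measured pair existed. The step is only a minimum, as the reading for compound 2 is a limit and not a number: the limit of > 200 mL.min-1.g-1 in this assay, at which 1 of the 3 values shown sits.

The step changes several things at once, as an aromatic carbon ring and its chlorine leave while a non-aromatic ring with a sulfur and two oxygen atoms enters, so the compounds shown do not say which of these parts accounts for the drop. As far as these compounds go, an unsubstituted phenyl or an oxan-4-yl group at the same nitrogen would help to separate these parts, and how far either would move the reading in this assay remains open.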